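The source may report more compounds than this note shows. Statements on the series, on what has been measured and on what is new or still open speak of the compounds shown alone.

In an ADME assay on microsomes from liver (Homo sapiens) for metabolic stability (on this read-out lower numbers stand for slow clearance and higher numbers for fast clearance), compound 3 `COc1ccc([C@H](C)NC(=O)Cn2nnc3ccccc3c2=O)cc1` gives 13 mL/min/kg, and compound 2 `Cc1cccc([C@H](C)NC(=O)Cn2nnc3ccccc3c2=O)c1` gives 11 mL/min/kg, a pair within the scatter of each other. Compound 1 `C[C@H](NC(=O)Cn1nnc2ccccc2c1=O)c1ccc(Cl)cc1` reads < 9.9 mL/min/kg, which is a limit of the assay and not a number. Compound 4 `C[C@H](NC(=O)Cn1nnc2ccccc2c1=O)c1ccc(F)cc1` carries fluoro in place of methoxy on an aromatic carbon, para to a large group (fluoro in place of methoxy on an aromatic carbon). The closest measured change, the one that brings in methoxy where chloro stood, is an at least 1.3-fold higher number from compound 1 to compound 3 (0.11 log units; that floor lies within the scatter). The other step into compound 3 is a 1.2-fold higher number from compound 2 to compound 3 (0.07 log units; within the scatter). Neither step leaves the scatter, so no change beyond it is expected in this assay. The expected step is a 1.2-fold lower number from compound 3 to compound 4 (0.07 log units; within the scatter). Compound 4 is estimated at 11 mL/min/kg, with an expected range of 8 mL/min/kg to 18 mL/min/kg.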

Compound 4, clearance: 31 mL/min/kg
For compound 4 the middle estimate is 2.8-fold (0.45 log units) below the measured one; the whole stated range lies below it.
By their numbers in this assay, from the lowest: compounds 2 and 3 (each within the scatter of the next); then compound 4. At a limit, below all of these: compound 1.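

In this assay, among the compounds shown here, the aromatic carbon para to a large group proves sensitive to the choice of group: fluoro in place of methoxy gives a 2.4-fold higher number from compound 3 to compound 4 (0.38 log units; beyond the scatter), whereas the earlier steps stayed within the scatter. The change from 3-methylphenyl to 4-fluorophenyl gives a 2.8-fold higher number from compound 2 to compound 4 (0.45 log units; beyond the scatter), so among these compounds only the fluoro compound 4 stands clearly apart. Fluoro in place of chloro gives an at least 3.1-fold higher number from compound 1 to compound 4 (0.49 log units; beyond the scatter), a floor only, as compound 1 is held at a limit of the assay: the limit of < 9.9 mL/min/kg in this assay, at which 1 of the 4 values shown sits.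

Going by these compounds, whether this rise belongs to fluoro alone stays open. So does where a nitrile, a trifluoromethyl or an amine at this place would fall.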